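Adding a Methoxy Group: From Compound 3 to Compound 4

The compounds below may be only part of what the source reports. "The series", "measured", "known", "first", "only" and "open" are said of these compounds alone.

Compound 1 `COc1ccc(-c2cc3cc(C4C(C#N)=C(N)OC5=C4C(=O)CC(C)(C)C5)cc(C)c3oc2=O)cc1OC` and compound 2 `COc1cc(-c2cc3cc(C4C(C#N)=C(N)OC5=C4C(=O)CC(C)(C)C5)cc(C)c3oc2=O)cc(OC)c1OC` share one core and differ by a single group. In a functional assay on the whole organism (strain Swiss albino) with Mus musculus as the target, in the forced swim test, with a stated time of 5 min, at a dose of 0.5 mg/kg by the intraperitoneal route (a higher number here means more inhibition at the dose given (going by the name of the read-out), a lower number less inhibition), compound 1 gives 10.4%, and compound 2 gives 6.37%. The change between them, (methoxy in place of hydrogen on an aromatic carbon), made a step of a number 4 percentage points lower from compound 1 to compound 2 (within the scatter), so the two values cannot be told apart.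

Compound 3 `COc1ccc(-c2cc3cc(C4C(C#N)=C(N)OC5=C4C(=O)CCC5)cc(C(C)(C)C)c3oc2=O)cc1` has a different core; how it differs from compound 1 is not broken down here. In this assay compound 3 gives 30.7%, the highest of the three values, with compound 1 lower and compound 2 lower still, both beyond the scatter.

Compound 4 `COc1ccc(-c2cc3cc(C4C(C#N)=C(N)OC5=C4C(=O)CCC5)cc(C(C)(C)C)c3oc2=O)cc1OC` is not yet measured. It differs from compound 3 by methoxy in place of hydrogen on an aromatic carbon. The same kind of change was made from compound 1 to compound 2, though the surroundings are not identical: in compound 2 the new group is also meta to a methoxy group, which is not the case in compound 4. Going by the one measured example, the step from compound 3 to compound 4 in this assay is expected to be a number 3.7 percentage points lower from compound 3 to compound 4 (within the scatter), small, resting on the step from compound 1 to compound 2 of a number 4 percentage points lower from compound 1 to compound 2 (within the scatter). Compound 4 is therefore estimated at 27%, plausibly between 12% and 42%.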

Compound 4, a percentage reported as inhibition, in the whole organism at one dose (the size of the read-out at that dose, not a potency): -16.6%
Beside the measured number, compound 4's estimate is 43.6 percentage points above it; measured number outside the range, below it.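

In this assay, putting methoxy in place of hydrogen on an aromatic carbon of compound 3, which turns 4-methoxyphenyl into 3,4-dimethoxyphenyl, gave a large step: a number 47.3 percentage points lower from compound 3 to compound 4 (beyond the scatter). The same kind of change therefore did not carry from one core to the other at a constant size, since on the core of compound 1 it could not be told from the scatter, while on the core of compound 3 it lay well beyond it: the same change on two cores in this assay, a number 4 percentage points lower (within the scatter) from compound 1 to compound 2 and a number 47.3 percentage points lower (beyond the scatter) from compound 3 to compound 4, 43.3 percentage points apart, beyond the scatter of two such steps. This does not show whether the gap comes from the differences between the two cores or from the surroundings of the new group, which in compound 4 is ortho to a methoxy group, and two steps give no rule for any further core in this series.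

The compounds shown leave open how other groups at the same aromatic carbon of the core of compound 3 would read out, for example an ethoxy group, a hydroxyl group or a fluorine atom. They also leave open how large the step from 4-methoxyphenyl to 3,4-dimethoxyphenyl would be on a third core.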